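The compounds below may be only part of what the source reports. "The series", "measured", "known", "first", "only" and "open" are said of these compounds alone.

Compound 1 `O=C(NCc1ccc(S(=O)(=O)c2cccc(C(F)(F)F)c2)cc1)N1Cc2ccncc2C1` gives 10000 nM
Compound 2 `O=C(NCc1ccc(S(=O)(=O)c2cc(F)cc(F)c2)cc1)N1Cc2ccncc2C1` gives 16000 nM
Compound 3 `CCC(=O)N1CCC(S(=O)(=O)c2ccc(CNC(=O)N3Cc4ccncc4C3)cc2)CC1` gives 216000 nM

These values come from a physicochemical assay for solubility, in phosphate buffer, with a stated time of 24 h, at pH 7.4, tested at 100 uM (a lower number here means a less soluble compound, a higher number a more soluble compound), and compound 3 stands highest of the three. The next change gives compound 4 `O=C(NCc1ccc(S(=O)(=O)N2CCC[C@H](O)C2)cc1)N1Cc2ccncc2C1` and is described by 3-hydroxypiperidin-1-yl in place of 1-propanoylpiperidin-4-yl on a sulfonyl sulfur in which 3-hydroxypiperidin-1-yl takes the place of 1-propanoylpiperidin-4-yl on a sulfonyl sulfur.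

Swapping one aromatic group for another on that sulfur changed little (a 1.6-fold higher number from compound 1 to compound 2 (0.20 log units; within the scatter)). Putting 1-propanoylpiperidin-4-yl there in place of an aromatic group gave two large steps (a 22-fold higher number from compound 1 to compound 3 (1.33 log units; beyond the scatter)) and (a 14-fold higher number from compound 2 to compound 3 (1.13 log units; beyond the scatter)). For the measured compounds named here, no measured step tests the new change itself. Still, compound 3 (216000 nM) and compound 4 both carry a six-membered non-aromatic ring at this place, so compound 4 should stay close to compound 3 rather than fall back towards the aromatic examples.

In this assay the expected step is a 1.4-fold lower number from compound 3 to compound 4 (0.16 log units; within the scatter) and nothing beyond the scatter is expected. For compound 4 the estimated value is 150000 nM (expected range 60000 nM to 300000 nM).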

Compound 4, solubility: 215000 nM
The estimate for compound 4 lay 1.4-fold (0.16 log units) below the measured number, and the stated range covers the measured number.
By their numbers in this assay, from the lowest: compounds 1 and 2 (each within the scatter of the next); then compounds 4 and 3 (each within the scatter of the next).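

In this assay, exchanging one six-membered non-aromatic ring for another on the sulfonyl sulfur leaves the number within the scatter (a 1.0-fold lower number from compound 3 to compound 4 (0.00 log units; within the scatter)), even though 3-hydroxypiperidin-1-yl has fewer heavy atoms than 1-propanoylpiperidin-4-yl. For the compounds shown here, compound 4 also keeps large steps over the aromatic examples (a 13-fold higher number from compound 2 to compound 4 (1.13 log units; beyond the scatter)) and (a 22-fold higher number from compound 1 to compound 4 (1.33 log units; beyond the scatter)), so the high number is no longer seen with only one non-aromatic group at this place. Nothing shown here explains why these two groups give such similar numbers.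

On these data alone, it remains open whether plain piperidin-1-yl, without the hydroxyl, or morpholin-4-yl, or an open chain such as diethylamino, would stay at this level. As far as these compounds go, the mirror-image form of 3-hydroxypiperidin-1-yl also remains open.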